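Methyl to Amino on a Pair at the Assay Limit

The compounds below may be only part of what the source reports. "The series", "measured", "known", "first", "only" and "open" are said of these compounds alone.

compound 1 `Cc1ccc(C(=O)Oc2ccc(O)c(C(C)(C)C)c2)cc1`: > 100000 nM
compound 2 `COc1ccccc1C(=O)Oc1ccc(O)c(C(C)(C)C)c1`: > 100000 nM

Two compounds were tested in an assay on isolated protein for antagonist activity at Bile acid receptor (Homo sapiens), read by HTRF, with a stated time of 30 min; on this read-out higher numbers stand for weaker inhibition and lower numbers for stronger inhibition. In it compound 1 gives > 100000 nM, which is a limit of the assay rather than a measured number. Compound 2 gives > 100000 nM, likewise a limit. Where compound 1 stands is thus described by the limit of > 100000 nM in this assay, at which 2 of the 2 values shown sit: no inhibition within the reportable range has been seen for either measured compound. Compound 3 `CC(C)(C)c1cc(OC(=O)c2ccc(N)cc2)ccc1O` has not been measured. It differs from compound 1 by amino in place of methyl on an aromatic carbon. Within the data shown here, no pair of measured compounds differing in one place exists, so no step size has been observed. Because compound 1 already sits at the limit of > 100000 nM in this assay, at which 2 of the 2 values shown sit, the expected step is a number no higher from compound 1 to compound 3 (the limit leaves the size open), none beyond the scatter. Compound 3 is expected to give 100000 nM, within 30000 nM to 300000 nM, most likely again as a limit.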

Compound 3, half-maximal inhibitory concentration: 34200 nM
The estimate for compound 3 lay 2.9-fold (0.47 log units) above the measured number, within the range that was stated.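

In this assay, amino in place of methyl on the aromatic carbon gives an at least 2.9-fold lower number from compound 1 to compound 3 (0.46 log units; beyond the scatter). This position is therefore not silent: a swap of one heavy atom here is enough to bring inhibition into the reportable range, which neither earlier compound reached. The true size of the step stays open on one side, because compound 1 carries only a limit and not a number: the limit of > 100000 nM in this assay, at which 2 of the 3 values shown sit.

A single swap cannot tell whether amino is special at this position, or whether a hydroxyl, a methylamino or a dimethylamino group in the same place would do as well, better or worse. The compounds shown also leave open whether the same swap would have a similar effect with an amide in place of the ester in the shared core.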